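The source may hold more compounds than are shown below. What is called first, only, known or untested is meant among the compounds shown, and "the series" means these compounds.

Of the compounds shown here, two built on one shared core have so far been measured in a functional assay on SMMC-7721 cells (Homo sapiens) for cytotoxicity, read by MTT assay, with a stated time of 72 h; on this read-out lower numbers stand for stronger inhibition and higher numbers for weaker inhibition. Compound 1 `CC(C)=C1C(=O)N(c2ccc(Cl)cc2)N(c2ccc(Cl)cc2)C1=O` gives 45600 nM, and compound 2 `O=C1C(=Cc2ccc(Cl)cc2)C(=O)N(c2ccc(Cl)cc2)N1c1ccc(Cl)cc1` gives 30900 nM. These two values lie within the scatter of each other, so the numbers do not separate compound 2 from compound 1. The next compound, compound 3 `O=C1C(=Cc2cccc(Cl)c2)C(=O)N(c2ccc(Cl)cc2)N1c1ccc(Cl)cc1`, holds the same atoms as compound 2, joined differently: 3-chlorophenyl in place of 4-chlorophenyl on a double-bonded chain carbon bound to a double-bonded ring carbon. It carries 3-chlorophenyl in place of 4-chlorophenyl on a double-bonded chain carbon bound to a double-bonded ring carbon. Going by the values given here, no measured pair isolates this change, so there is no direct precedent for it. Compound 1 has no chlorophenyl group on that carbon, yet its 45600 nM sits within the scatter of compound 2 at 30900 nM. On that basis, no step beyond the scatter is expected in this assay, and no direction is favoured. The estimated 1.0-fold lower number from compound 2 to compound 3 (0.01 log units; within the scatter) is accordingly expected to stay within the scatter. For compound 3 the expected value is 30000 nM, with an estimated range of 14000 nM to 65000 nM.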

Compound 3, half-maximal inhibitory concentration: 20200 nM
Compound 3: middle estimate off by 1.5-fold (0.17 log units), on the high side; the range from low to high includes it.
By their numbers in this assay, from the lowest: compounds 3, 2 and 1 (each within the scatter of the next, the first and the last beyond it).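

Going by these compounds alone, the swap of 3-chlorophenyl for 4-chlorophenyl on a double-bonded chain carbon bound to a double-bonded ring carbon gives the first measured pair that isolates a single change at this position, and in this assay it amounts to a 1.5-fold lower number from compound 2 to compound 3 (0.18 log units; within the scatter). With the same atoms joined differently, this assay does not separate the two chlorophenyl groups at this position, so neither can be ranked above the other on these numbers. The pair therefore supplies a direct precedent that was missing before, though only for this one change, and no available measurement accounts for the result.

The compounds shown leave open whether a different kind of group on that carbon would produce a step beyond the scatter, such as 2-chlorophenyl, an aminophenyl group, a carboxyphenyl group or a longer chain in place of the 3-chlorophenyl. They also leave open whether the two chlorophenyl groups would still read alike on the shared core in a different cell line.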